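Fluoro in place of methoxy: an expected step

The source may report more compounds than this note shows. Statements on the series, on what has been measured and on what is new or still open speak of the compounds shown alone.

In a functional assay on A549 cells (Homo sapiens) for antiproliferative activity, read by MTT assay, with a stated time of 48 h (a higher number here means a weaker inhibitor, a lower number a stronger inhibitor), compound 2 `COc1ccc(C(=O)/C=C/c2cccc(Br)c2Oc2c([N+](=O)[O-])cc(C(F)(F)F)cc2[N+](=O)[O-])cc1` gives 12.7 ug/mL. Going by the values given here, compound 1 `COc1ccc(C(=O)/C=C/c2cc(Br)cc(Br)c2Oc2c([N+](=O)[O-])cc(C(F)(F)F)cc2[N+](=O)[O-])cc1` gives 13.2 ug/mL, and these two values lie within the scatter of each other, so compound 2 stands level with the only other measured compound. Compound 3 `O=C(/C=C/c1cccc(Br)c1Oc1c([N+](=O)[O-])cc(C(F)(F)F)cc1[N+](=O)[O-])c1ccc(F)cc1` is still unmeasured. It differs from compound 2 by fluoro in place of methoxy on an aromatic carbon, para to a large group, so that 4-methoxyphenyl becomes 4-fluorophenyl: fluoro in place of methoxy on an aromatic carbon.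

Among the compounds with values here, only one measured step exists, a 1.0-fold lower number from compound 1 to compound 2 (0.02 log units; within the scatter), and it is a different change, hydrogen in place of bromo on an aromatic carbon. It bears on the new change only indirectly, showing that one substitution on this scaffold left the number within the scatter. Within the data shown here, no measured compound varies the methoxy group, so the data offer no direction for this swap. The expected result in this assay is therefore no shift beyond the scatter, with a 1.0-fold higher number from compound 2 to compound 3 (0.01 log units; within the scatter) as the estimated step. For compound 3 the estimate is 13 ug/mL, with an expected range from 6.5 ug/mL to 26 ug/mL.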

Compound 3, half-maximal inhibitory concentration: 26.3 ug/mL
Beside the measured number, compound 3's estimate is 2.0-fold (0.31 log units) below it, and the stated range ends below it.
By their numbers in this assay, from the lowest: compounds 2, 1 and 3 (each within the scatter of the next, the first and the last beyond it).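

In this assay, going by these compounds alone, putting fluoro in place of methoxy on the aromatic carbon para to a large group gives a 2.1-fold higher number from compound 2 to compound 3 (0.32 log units; beyond the scatter), the first step in this small set to pass beyond the scatter. This marks the 4-methoxyphenyl end as a place where the number responds to substitution, and the response is toward a weaker inhibitor, although the step is modest. The bromo change, a 1.0-fold lower number from compound 1 to compound 2 (0.02 log units; within the scatter), had shown no such response, so the scaffold does not tolerate every substitution equally in this assay. Nothing available accounts for the shift, so the result stands as an observation without an explanation.

Among the compounds shown, only methoxy and fluoro are compared at this position, so it remains open whether the difference follows the departure of methoxy or the arrival of fluoro, a question that a hydroxy, ethoxy, methyl or dimethylamino group there could help to separate. On these data alone, it is also open whether the same swap gives a step of similar size on the core of compound 1, with its additional bromo.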